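Replacing the hydrazone arm on the shared core

The source may report more compounds than this note shows. Statements on the series, on what has been measured and on what is new or still open speak of the compounds shown alone.

Measured so far in a functional assay on HeLa cells (Homo sapiens) for inhibition, read by MTT assay, with a stated time of 48 h; a higher number here means a weaker inhibitor, a lower number a stronger inhibitor:
compound 1 `CCOC(=O)C1=C(N/N=C(\C#N)C(N)=O)Nc2[nH]nc(C)c2C1c1ccc(N(C)C)cc1`: 47300 nM
compound 2 `CCOC(=O)C1=C(N/N=C(/Cl)c2ccc([N+](=O)[O-])cc2)Nc2[nH]nc(C)c2C1c1ccc(N(C)C)cc1`: 46200 nM

Compound 1 and compound 2 share a core and differ only on the amine nitrogen; the step of a 1.0-fold lower number from compound 1 to compound 2 (0.01 log units; within the scatter) shows that this replacement leaves this assay unmoved. Compound 3 `CCOC(=O)C1=C(N/C=N/c2ccc([N+](=O)[O-])cc2)Nc2[nH]nc(C)c2C1c1ccc(N(C)C)cc1` carries a further variation at the same place: a group of 11 heavy atoms (7 carbon, 2 nitrogen, 2 oxygen; one six-membered aromatic ring of carbon only) in place of a group of 7 heavy atoms (3 carbon, 3 nitrogen, 1 oxygen; no ring), on an amine nitrogen. Going by the values given here, the only step that bears on it is the one from compound 1 to compound 2, which was flat, so no change beyond the scatter is expected for a 1.0-fold lower number from compound 1 to compound 3 (0.00 log units; within the scatter). Compound 3 is therefore estimated at 47000 nM in this assay, within a range from 20000 nM to 110000 nM.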

Compound 3, half-maximal inhibitory concentration: 57800 nM
Estimate against measurement, compound 3: 1.2-fold (0.09 log units) below; the range from low to high includes it.
By their numbers in this assay, from the lowest: compounds 2, 1 and 3 (each within the scatter of the next).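

In this assay the step of a 1.2-fold higher number from compound 1 to compound 3 (0.09 log units; within the scatter) shows that a group with one six-membered aromatic ring of carbon only and 0 hydrogen-bond donors also leaves the number unmoved on this amine nitrogen. The step of a 1.3-fold higher number from compound 2 to compound 3 (0.10 log units; within the scatter) shows the same for a group without the chlorine of compound 2, so all three groups read alike here. No evidence on why they read alike is at hand.

Going by these compounds, whether a carboxylic acid or a longer alkyl chain on this nitrogen would move the number beyond the scatter stays open. Changes elsewhere on the shared core also stay open.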